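Swapping Trifluoromethylphenyl for Chlorophenyl on the Benzyl Arm

This account rests on a few compounds, and the source may have more. Where it says the series, first, only, none or still open, it means among the compounds named here.

Compound 3 `O=S(=O)(NCCCNCc1ccc(C(F)(F)F)cc1)c1cc(C(F)(F)F)cc(C(F)(F)F)c1` stands second highest of three numbers in a functional assay on Capan-2 cells (Homo sapiens) for inhibition, read by MTT assay, with a stated time of 72 h; on this read-out lower numbers stand for stronger inhibition of growth and higher numbers for weaker inhibition of growth: compound 3 gives 2000 nM. Compound 2 `O=S(=O)(NCCCNCc1ccc(Cl)c(Cl)c1)c1cc(C(F)(F)F)cc(C(F)(F)F)c1` gives 1800 nM in this assay, and compound 1 `O=S(=O)(NCCCNCc1ccccc1Cl)c1cc(C(F)(F)F)cc(C(F)(F)F)c1` gives 13000 nM. The steps seen so far in this assay were a 7.2-fold lower number from compound 1 to compound 2 (0.86 log units; beyond the scatter), a 6.5-fold lower number from compound 1 to compound 3 (0.81 log units; beyond the scatter) and a 1.1-fold higher number from compound 2 to compound 3 (0.05 log units; within the scatter). Compound 4 `O=S(=O)(NCCCNCc1cccc(Cl)c1)c1cc(C(F)(F)F)cc(C(F)(F)F)c1` differs from compound 3 by 3-chlorophenyl in place of 4-(trifluoromethyl)phenyl on a saturated chain carbon bound to an amine nitrogen. Among the measured compounds shown here, no measured step pairs a single chlorine on the ring with either of the other groups; the measured steps show only that 2-chlorophenyl trails 3,4-dichlorophenyl and 4-(trifluoromethyl)phenyl, which sit together. A step of a 2.0-fold higher number from compound 3 to compound 4 (0.30 log units; within the scatter) is therefore expected, a modest rise with wide uncertainty. Compound 4 is expected to give about 4000 nM, between 1500 nM and 12000 nM.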

Compound 4, concentration for 50% growth inhibition: 8000 nM
Beside the measured number, compound 4's estimate is 2.0-fold (0.30 log units) below it; measured number inside the range.
By their numbers in this assay, from the lowest: compounds 2 and 3 (each within the scatter of the next); then compounds 4 and 1 (each within the scatter of the next).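

In this assay, a single chlorine does not match the 4-(trifluoromethyl)phenyl group at this place, with a 4.0-fold higher number from compound 3 to compound 4 (0.60 log units; beyond the scatter). Hydrogen in place of chloro on an aromatic carbon gives a 4.4-fold higher number from compound 2 to compound 4 (0.65 log units; beyond the scatter), while 3-chlorophenyl in place of 2-chlorophenyl gives a 1.6-fold lower number from compound 1 to compound 4 (0.21 log units; within the scatter), so the two monochloro compounds sit together, apart from compounds 2 and 3. Nothing available explains these steps. The compounds shown leave open how a methoxyphenyl or a pyridine ring would fare on this carbon. They also leave open whether a longer chain would change this ranking.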